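A few compounds are considered here, and "the series" means these few. Any claim that something is new, unique, unknown or untested is made for them only; others in the source may bear on it.

Compound 1, `CC/C=C\C(=O)Nc1cc(Nc2nccc(-c3cn(C)c4ccccc34)n2)c(OC)cc1N(C)CCN(C)C`: 6670 nM.
Compound 2, `CCC/C=C\C(=O)Nc1cc(Nc2nccc(-c3cn(C)c4ccccc34)n2)c(OC)cc1N(C)CCN(C)C`: 431 nM.
Compound 3, `CC/C=C\C(=O)Nc1cc(Nc2nccc(-c3cn(C)c4ccc(F)cc34)n2)c(OC)cc1N(C)CCN(C)C`: 5290 nM.

All three were tested in a functional assay on HepG2 cells (Homo sapiens) for antiproliferative activity, read by MTT assay, with a stated time of 72 h; on this read-out higher numbers stand for weaker inhibition and lower numbers for stronger inhibition. Compound 2 differs from compound 1 by methyl in place of hydrogen on a saturated chain carbon, two bonds along the chain from a double-bonded chain carbon, and that change gave a 15-fold lower number from compound 1 to compound 2 (1.19 log units; beyond the scatter). Compound 3 carries a different core, (fluoro in place of hydrogen on an aromatic carbon), which gave a 1.3-fold lower number from compound 1 to compound 3 (0.10 log units; within the scatter). Compound 4, `COc1cc(N(C)CCN(C)C)c(NC(=O)/C=C\C(C)C)cc1Nc1nccc(-c2cn(C)c3ccc(F)cc23)n1`, is not yet measured; it differs from compound 3 by methyl in place of hydrogen on a saturated chain carbon bound to a double-bonded chain carbon and a saturated chain carbon. This is the same kind of change as that from compound 1 to compound 2 but not the same: there the methyl entered on a saturated chain carbon two bonds along the chain from a double-bonded chain carbon, here on a saturated chain carbon bound to a double-bonded chain carbon and a saturated chain carbon. Because a 15-fold lower number from compound 1 to compound 2 (1.19 log units; beyond the scatter) was large, a lower number is expected for compound 4 than for compound 3, though a smaller step since the place is not the same. For compound 4 the step is estimated as a 4.4-fold lower number from compound 3 to compound 4 (0.64 log units; beyond the scatter). Compound 4 is thus expected at 1200 nM, likely between 350 nM and 4000 nM.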

Compound 4, half-maximal inhibitory concentration: 3920 nM
Estimate against measurement, compound 4: 3.3-fold (0.51 log units) below, within the range that was stated.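

On the fluoro-bearing core, the added methyl gave a 1.3-fold lower number from compound 3 to compound 4 (0.13 log units; within the scatter) in this assay, so the large drop seen on the core of compound 1 did not carry over. The two steps clearly differ: the same change on two cores in this assay, a 15-fold lower number (1.19 log units; beyond the scatter) from compound 1 to compound 2 and a 1.3-fold lower number (0.13 log units; within the scatter) from compound 3 to compound 4, 11-fold (1.06 log units) apart, beyond the scatter of two such steps This does not show whether the fluoro group or the place of the methyl accounts for the gap, as the methyl sits on a different chain carbon in each step and these two steps cannot separate the two.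

The compounds shown leave open what the 3-methylbut-1-en-1-yl chain does on the core of compound 1, and what the chain of compound 2 does on the core of compound 3. They also leave open how a longer chain or a chain carrying an amine would fare on either core.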